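A few compounds are considered here, and "the series" means these few. Any claim that something is new, unique, unknown or untested is made for them only; others in the source may bear on it.

Working notes on the series. Within the data shown here, compound 1, `CCC(=O)Nc1ccc(-c2nc3cc(C(F)(F)F)ccc3[nH]2)cc1`, is the anchor of the set in an ADME assay on BHK cells (Mesocricetus auratus) for cytotoxicity, read by MTT assay, with a stated time of 96 h; on this read-out higher numbers stand for lower toxicity in this test and lower numbers for higher toxicity in this test: compound 1 gives 100000 nM, and this is the only plain number among the three values. Compound 2, `CCC(=O)Nc1ccc(-c2nc3cc(C(F)(F)F)ccc3n2C)cc1`, carries methyl in place of hydrogen on an aromatic nitrogen. In this assay compound 2 reaches only a limit, > 100000 nM. Compound 3, `CCC(=O)Nc1ccc(-c2nc3ccccc3[nH]2)cc1`, carries hydrogen in place of trifluoromethyl on an aromatic carbon. In this assay compound 3 also stops at a limit, >= 100000 nM. The two measured steps are a number no lower from compound 1 to compound 2 (the limit leaves the size open) and a number no lower from compound 1 to compound 3 (the limit leaves the size open); each rests on a limit, the limit of > 100000 nM in this assay, at which 1 of the 3 values shown sits, and (the limit of >= 100000 nM in this assay, at which 1 of the 3 values shown sits), so neither has a readable size, and both change the core side of the molecule rather than the amide chain.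

Compound 4, `O=C(CN1CCCCC1)Nc1ccc(-c2nc3cc(C(F)(F)F)ccc3[nH]2)cc1`, is not yet measured. It differs from compound 1 by piperidin-1-yl in place of methyl on a saturated chain carbon bound to a carbonyl carbon. Among the measured compounds shown here, no measured step touches this part of the structure, so the measured steps bear on the change only by showing that all three compounds so far sit at or near the top of the tested range. The step is therefore expected to be a 1.4-fold lower number from compound 1 to compound 4 (0.15 log units; within the scatter), with no direction supported beyond the scatter. For compound 4 the estimate in this assay is 70000 nM, within 20000 nM to 100000 nM.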

Compound 4, half-maximal cytotoxic concentration: 12000 nM
Beside the measured number, compound 4's estimate is 5.8-fold (0.77 log units) above it, outside the stated range (below it).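

In this assay, among these compounds, the saturated chain carbon bound to a carbonyl carbon is the first place in the set to give a step of readable size: piperidin-1-yl in place of methyl gives an 8.3-fold lower number from compound 1 to compound 4 (0.92 log units; beyond the scatter), and on this read-out the lower number stands for higher toxicity in this test. The changes on the core side, in compound 2 and compound 3, give steps that cannot be read in size, so the amide chain is the only part of the structure with a measured effect on this number, and that effect rests on a single pair. Nothing shown here bears on why this change lowers the number.

The compounds shown leave open whether the step follows the ring or the nitrogen of piperidin-1-yl, which a cyclohexyl group or an open-chain diethylamino group on the same carbon would separate. Also open, going by these compounds, is whether piperidin-1-yl gives a step of the same size on the core of compound 3, with hydrogen in place of trifluoromethyl, or whether a longer chain between the carbonyl and the ring changes it.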